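Methyl in place of hydrogen: from compound 3 to compound 4

A few compounds are considered here, and "the series" means these few. Any claim that something is new, unique, unknown or untested is made for them only; others in the source may bear on it.

Compound 1 `Cc1ccc2nc(Nc3nc(Nc4ccc(S(N)(=O)=O)cc4)ncc3C)sc2c1`: in a functional assay on MCF7 cells (Homo sapiens) for antiproliferative activity, read by MTT assay, with a stated time of 48 h (on this read-out lower numbers stand for stronger inhibition and higher numbers for weaker inhibition), compound 1 reaches only a limit, > 50000 nM.
Compound 2 `Cc1cnc(Nc2ccc(S(N)(=O)=O)cc2)nc1Nc1nc2ccccc2s1`: compound 2 likewise stops at a limit, > 50000 nM.
Compound 3 `NS(=O)(=O)c1ccc(Nc2nccc(Nc3nc4ccc(F)cc4s3)n2)cc1`: compound 3 gives 10900 nM.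

For the measured compounds named here, compound 3 holds the only number in the set; the other two entries are limits, as the limit of > 50000 nM in this assay, at which 2 of the 3 values shown sit, records. Compound 4 `Cc1cnc(Nc2ccc(S(N)(=O)=O)cc2)nc1Nc1nc2ccc(F)cc2s1` arises from compound 3 by methyl in place of hydrogen on an aromatic carbon. Going by the values given here, the single measured step touching this change, a step that the two limits leave unreadable from compound 1 to compound 2, cannot be sized, since both of its ends are limits. Compound 2, which shares the methyl with compound 4, reports only a limit. Compound 3, without that methyl, gives a number. Going by these compounds, the size of the step stays open. A step towards weaker inhibition is expected, a 2.3-fold higher number from compound 3 to compound 4 (0.36 log units; beyond the scatter). Compound 4 is estimated at 25000 nM, between 8000 nM and 60000 nM.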

Compound 4, half-maximal inhibitory concentration: > 50000 nM
Compound 4 gave a limit, no number (the forecaster's own chance of this, stated with the estimate: 40%); middle value at least 2.0-fold (0.30 log units) away from the limit.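

In this assay, methyl in place of hydrogen on this aromatic carbon, two atoms from the ring nitrogen, now has a readable lower bound: an at least 4.5-fold higher number from compound 3 to compound 4 (0.66 log units; beyond the scatter). The earlier compounds shown here gave only a step with limits at both ends, and compound 4 shows that fluoro does not keep a number once the methyl is present. The steps from compound 1 and compound 2 to compound 4 cannot be read, and the set crowds at one limit: the limit of > 50000 nM in this assay, at which 3 of the 4 values shown sit.

Going by these compounds, the full size of the methyl step remains open. So does whether an amine or a chloro group at this carbon would return a number.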